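Replacing 3,5-dimethoxyphenyl with 3-(trifluoromethyl)phenyl

The source may hold more compounds than are shown below. What is called first, only, known or untested is meant among the compounds shown, and "the series" means these compounds.

Going by the values given here, in a functional assay on MDA-MB-231 cells (Homo sapiens) for antiproliferative activity, read by MTT assay, with a stated time of 72 h (a higher number here means a weaker inhibitor, a lower number a stronger inhibitor), compound 2 `COc1cc(OC)cc(-c2cccc(NC(=O)CCc3cccc4c3B(O)OC4)c2)c1` gives 40 nM, the lower of the two numbers so far, and compound 1 `C#Cc1cccc(NC(=O)CCc2cccc3c2B(O)OC3)c1` gives 1600 nM. Compound 3 `O=C(CCc1cccc2c1B(O)OC2)Nc1cccc(-c2cccc(C(F)(F)F)c2)c1` carries 3-(trifluoromethyl)phenyl in place of 3,5-dimethoxyphenyl on an aromatic carbon. Among the compounds with values here, the only measured step at this place is the large 40-fold lower number from compound 1 to compound 2 (1.60 log units; beyond the scatter), where 3,5-dimethoxyphenyl replaced ethynyl. Within the data shown here, compound 3 keeps a six-membered aromatic ring there, but no measured step compares two such groups. The expected change is a 1.5-fold higher number from compound 2 to compound 3 (0.18 log units; within the scatter), a slightly higher number within the scatter. Compound 3 is estimated at 60 nM, with an expected range of 20 nM to 200 nM.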

Compound 3, half-maximal inhibitory concentration: 410 nM
Compound 3: middle estimate off by 6.8-fold (0.83 log units), on the low side, outside the stated range (above it).
By their numbers in this assay, from the lowest: compound 2; then compound 3; then compound 1.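

In this assay, the step with a 10-fold higher number from compound 2 to compound 3 (1.01 log units; beyond the scatter) shows that two phenyl groups of equal heavy-atom count are not interchangeable at this position, which the ethynyl comparison could not reveal. 3-(Trifluoromethyl)phenyl still improves on ethynyl, with a 3.9-fold lower number from compound 1 to compound 3 (0.59 log units; beyond the scatter) as its step, so only part of the drop seen with 3,5-dimethoxyphenyl is retained. No evidence is available that explains the difference between these two groups.

Still open, from the compounds shown here alone, is whether compound 2 depends on both methoxy groups or on one alone, and how an amine or a carboxylic acid on this phenyl ring would read.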